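Mirror Image of a Potent Nicotinic Receptor Agonist

The source may report more compounds than this note shows. Statements on the series, on what has been measured and on what is new or still open speak of the compounds shown alone.

Within the data shown here, compound 3 `COc1cc(N2CC[C@H]3CN[C@H]3C2)cnc1Br` gives 8 nM in a functional assay on HEK293 cells for agonist activity at Neuronal acetylcholine receptor; alpha3/beta4 (Homo sapiens), read by FLIPR (on this read-out lower numbers stand for an effect already at smaller amounts and higher numbers for an effect only at larger amounts of compound), the lowest of the three numbers known so far. Compound 1 `Brc1cc(N2CC[C@@H]3CN[C@@H]3C2)cnc1Br` gives 110 nM and compound 2 `COc1cncc(N2CC[C@@H]3CN[C@@H]3C2)c1` gives 4500 nM in this assay; both numbers lie beyond the scatter from that of compound 3. Compound 4 `COc1cc(N2CC[C@@H]3CN[C@@H]3C2)cnc1Br` has not yet been measured. Its difference from compound 3 is this: the two compounds have the same atoms and bonds and differ only in configuration as drawn: 2 of 2 stereo elements differ (all stereocentres are inverted: mirror images); a stereocentre at a saturated ring carbon is drawn S in compound 3 and R in compound 4; a stereocentre at a saturated ring carbon is drawn R in compound 3 and S in compound 4. Compounds 1 and 2 share the configuration drawn for compound 4, and their numbers are higher than that of compound 3, although neither is a single-change step from it. An upward shift in this assay is therefore expected, of the size a 19-fold higher number from compound 3 to compound 4 (1.27 log units; beyond the scatter). Compound 4 is estimated at 150 nM, within 15 nM to 1500 nM.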

Compound 4, half-maximal effective concentration: 160 nM
The estimate for compound 4 lay 1.1-fold (0.03 log units) below the measured number, within the range that was stated.
By their numbers in this assay, from the lowest: compound 3; then compounds 1 and 4 (each within the scatter of the next); then compound 2.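

In this assay the new result is a 20-fold higher number from compound 3 to compound 4 (1.30 log units; beyond the scatter), and this gap can be traced to stereochemistry alone: the fact that compounds 3 and 4 differ only in the configuration as drawn. Within the configuration of compound 4, bromo in place of hydrogen on an aromatic carbon gives a 28-fold lower number from compound 2 to compound 4 (1.45 log units; beyond the scatter), so this added bromo matters greatly. Methoxy in place of bromo on an aromatic carbon gives a 1.5-fold higher number from compound 1 to compound 4 (0.16 log units; within the scatter), so this swap shows no real change.

As far as these compounds go, whether inverting the configuration of compounds 1 and 2 would shift their numbers in the same way remains open. So does how an amine or a longer chain in place of the methoxy would read.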